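Extending the Side Chain of Compound 2

The compounds below may be only part of what the source reports. "The series", "measured", "known", "first", "only" and "open" are said of these compounds alone.

Of the compounds shown here, three sharing one core have been measured in a functional assay on the whole organism (strain Fischer 344) for inhibition, with Rattus norvegicus as the target, read by paw edema, at a dose of 0.01 mmol/kg by the intraperitoneal route; on this read-out higher numbers stand for more inhibition at the one dose given (going by the name of the read-out) and lower numbers for less inhibition. Compound 1 `Cn1c(=O)c(C(=O)NCCN)c(O)c2ccccc21` gives 67%. Compound 2 `NCCNC(=O)c1c(O)c2ccccc2n(-c2ccccc2)c1=O` gives 68.1% in this assay, and compound 3 `Nc1ccccc1NC(=O)c1c(O)c2ccccc2n(-c2ccccc2)c1=O` gives 48.5%. Compound 2 thus holds the highest of the three numbers, though one neighbouring step is only a number 1.1 percentage points higher from compound 1 to compound 2 (within the scatter), while the other step is larger, with a number 19.6 percentage points lower from compound 2 to compound 3 (beyond the scatter).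

Compound 4 `O=C(CCCCC1CCSS1)NCCNC(=O)c1c(O)c2ccccc2n(-c2ccccc2)c1=O` differs from compound 2 by a group of 11 heavy atoms (8 carbon, 1 oxygen, 2 sulfur; one five-membered non-aromatic ring with 2 hetero atoms) in place of a hydrogen atom, on an amine nitrogen. Neither measured step touches this nitrogen: the change from compound 1 to compound 2 concerns an aromatic nitrogen and stays within the scatter, and the change to compound 3 replaces the whole 2-aminoethyl group on the amide-type nitrogen. Because a number 19.6 percentage points lower from compound 2 to compound 3 (beyond the scatter) is the only measured alteration of the side chain and it lowered the number, a modest loss is expected for compound 4, though a result within the scatter remains plausible. The step expected is a number 13.1 percentage points lower from compound 2 to compound 4 (beyond the scatter). Compound 4 is therefore estimated at 55%, with a range from 35% to 75%.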

Compound 4, a percentage reported as inhibition, in the whole organism at one dose (the size of the read-out at that dose, not a potency): 45.5%
Estimate against measurement, compound 4: 9.5 percentage points above, within the range that was stated.
By their numbers in this assay, from the lowest: compounds 4 and 3 (each within the scatter of the next); then compounds 1 and 2 (each within the scatter of the next).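

Among the compounds shown here, this is the first change at the amine nitrogen at the end of the side chain, where the earlier compounds all carry the free amine. In this assay, the step is a number 22.6 percentage points lower from compound 2 to compound 4 (beyond the scatter), so this nitrogen does not accept the new group, with its five-membered ring holding two sulfur atoms, without a loss of inhibition at the one dose given. Nothing shown here explains the drop.

The compounds shown leave open whether the loss follows from replacing the amine hydrogen at all, or from the chain or the ring of the added group. A small acetyl group on the same nitrogen, or a plain unbranched chain of similar length without the ring, would help separate these possibilities.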